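This account rests on a few compounds, and the source may have more. Where it says the series, first, only, none or still open, it means among the compounds named here.

In a functional assay on A549 cells (Homo sapiens) for antiproliferative activity, read by MTT assay, with a stated time of 72 h (on this read-out lower numbers stand for stronger inhibition and higher numbers for weaker inhibition), compound 3 `COc1cc2ncnc(N3CCCc4ccccc43)c2cc1NC(=O)C=C(C)C` gives 5410 nM. This lies within the scatter of compound 2 `CC(C)/C=C/C(=O)Nc1cc2c(N3CCc4ccccc43)ncnc2cc1O[C@@H]1CCOC1` at 8520 nM, while compound 1 `C=C(C)C(=O)Nc1cc2c(N3CCc4ccccc43)ncnc2cc1O[C@@H]1CCOC1`, at 16600 nM, stands beyond the scatter on the higher side of compound 3. Compound 4 `CCC/C=C/C(=O)Nc1cc2c(N3CCCc4ccccc43)ncnc2cc1OC` differs from compound 3 by a single change on a carbonyl carbon: pent-1-en-1-yl in place of 2-methylprop-1-en-1-yl on a carbonyl carbon. Going by the values given here, the only measured step at that carbonyl carbon is a 1.9-fold lower number from compound 1 to compound 2 (0.29 log units; within the scatter), which lies within the scatter, and it involves different groups on a different core. Resting on that step, no shift beyond the scatter is expected in this assay, and the expected change is a 1.1-fold higher number from compound 3 to compound 4 (0.04 log units; within the scatter). Compound 4 is estimated at 6000 nM, with an expected range of 2500 nM to 14000 nM.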

Compound 4, half-maximal inhibitory concentration: 1800 nM
For compound 4 the middle estimate is 3.3-fold (0.52 log units) above the measured one; the whole stated range lies above it.
By their numbers in this assay, from the lowest: compound 4; then compounds 3, 2 and 1 (each within the scatter of the next, the first and the last beyond it).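

In this assay, going by these compounds alone, pent-1-en-1-yl in place of 2-methylprop-1-en-1-yl on a carbonyl carbon gives a 3.0-fold lower number from compound 3 to compound 4 (0.48 log units; beyond the scatter), the first step at this place that lies beyond the scatter. The group on this carbonyl carbon can therefore move the number, even though both groups have one double bond and no ring. Nothing measured here accounts for the shift. On these data alone, whether a longer chain, or a chain ending in an amine, would lower the number further remains open. So does whether the same change would hold on the core of compound 2.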